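The compounds below may be only part of what the source reports. "The series", "measured", "known", "first", "only" and "open" are said of these compounds alone.

Of the compounds shown here, two have so far been tested in a functional assay on HeLa cells (Homo sapiens) for cytotoxicity, read by MTT assay, with a stated time of 24 h; on this read-out lower numbers stand for stronger inhibition and higher numbers for weaker inhibition. Compound 1 `[N-]=[N+]=Nc1cc2ccc(O)cc2oc1=O` is the smaller of the two; in this assay compound 1 gives 41600 nM. Compound 2 `NCCC(=O)N1Cc2ccccc2-c2nnn(-c3cc4cc(Br)ccc4oc3=O)c2-c2ccccc21` is a larger molecule that carries a bromo group on one of its aromatic rings, and in this assay compound 2 gives 18200 nM. Of these two numbers, compound 2 has the lower one, and its gap to compound 1 lies beyond the usual scatter, so on this read-out compound 2 counts as the stronger of the pair.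

Compound 3 `NCCC(=O)N1Cc2ccccc2-c2nnn(-c3cc4ccccc4oc3=O)c2-c2ccccc21` has not yet been measured. It differs from compound 2 in a single place: hydrogen in place of bromo on an aromatic carbon. Everything else in the molecule stays as it is. Within the data shown here, no measured pair in this set shows what removing a bromo group does here, so the expectation rests only on how small the change is. The step is expected to be modest, tending toward a somewhat higher number, and most likely within the scatter. On that basis compound 3 is expected to give 26000 nM, with a range from 11000 nM to 60000 nM. The expected step is a 1.4-fold higher number from compound 2 to compound 3 (0.15 log units; within the scatter).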

Compound 3, half-maximal inhibitory concentration: 19800 nM
Estimate against measurement, compound 3: 1.3-fold (0.12 log units) above, within the range that was stated.
By their numbers in this assay, from the lowest: compounds 2 and 3 (each within the scatter of the next); then compound 1.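

In this assay, putting hydrogen in place of bromo on this aromatic carbon gives a 1.1-fold higher number from compound 2 to compound 3 (0.04 log units; within the scatter), a step within the usual scatter, so the two values cannot be told apart. Among these compounds, the earlier compounds offered no pair that differed in one place, and this pair now gives the first direct reading at this position. In these two molecules, the single bromine atom makes no measurable difference on this read-out, and the cytotoxicity seen here does not depend on it. No available measurement gives a reason for this result.

Going by these compounds, only bromo and hydrogen have been compared at this position, so it remains open whether another group there, such as a methoxy group or a carboxylic acid, would give a number that differs beyond the scatter. On these data alone, it also remains open how much the rest of the molecule contributes, for example whether a longer chain in place of the one that ends in the amine would shift the value in this assay.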